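The compounds below may be only part of what the source reports. "The series", "measured", "known", "first", "only" and "open" are said of these compounds alone.

Of the compounds shown here, two have been read in a physicochemical assay for lipophilicity, read by HPLC; on this read-out lower numbers stand for lower lipophilicity and higher numbers for higher lipophilicity. Compound 1 `COc1ccc(NC[C@H](O)COc2ccc(N3C[C@H](CNC(C)=O)OC3=O)cc2F)cc1` gives 0.95 in this assay. Compound 2 `CC(=O)NC[C@H]1CN(c2ccc(OC[C@@H](O)CNc3cc(C(F)(F)F)cc(C(F)(F)F)c3)c(F)c2)C(=O)O1` gives 3.1, the higher of the two numbers, the gap to compound 1 lying beyond the scatter. Compound 3 `CC(=O)NC[C@H]1CN(c2ccc(OC[C@H](O)CNc3cc(C(F)(F)F)cc(C(F)(F)F)c3)c(F)c2)C(=O)O1` is not yet measured; relative to compound 2 the change is the two compounds have the same atoms and bonds and differ only in configuration as drawn: 1 of 2 stereo elements differ; a stereocentre at a saturated chain carbon is drawn S in compound 2 and R in compound 3. With atoms and bonds unchanged, no shift beyond the scatter is expected, so the step from compound 2 to compound 3 is estimated at no change at the digits printed from compound 2 to compound 3 (within the scatter). Compound 3 is therefore expected to give 3.1, within 2.7 to 3.5.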

Compound 3, partition coefficient: 3.01
The estimate for compound 3 lay 0.09 log units above the measured number, within the range that was stated.
By their numbers in this assay, from the lowest: compound 1; then compounds 3 and 2 (each within the scatter of the next).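

In this assay, inverting the stereocentre at a saturated chain carbon from S to R gives a number 0.09 log units lower from compound 2 to compound 3 (within the scatter). This is the series' first step that changes one place only, and it shows that this stereocentre, drawn either way, leaves the read-out unchanged within the scatter for this substitution pattern. The comparison is confined to a single stereo element: the fact that compounds 2 and 3 differ only in the configuration as drawn.

Going by these compounds, whether the configuration stays equally silent with a carboxylic acid or an amine in place of the trifluoromethyl groups remains open. So does the effect of inverting the second stereo element, which is drawn alike in both compounds.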